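A few compounds are considered here, and "the series" means these few. Any claim that something is new, unique, unknown or untested is made for them only; others in the source may bear on it.

In a functional assay on HOS-TE85 cells (Homo sapiens) for inhibition, read by CCK-8 assay, with a stated time of 72 h (on this read-out higher numbers stand for weaker inhibition and lower numbers for stronger inhibition), compound 1 `O=C(NCCCCn1cccn1)c1cccc(C2SCC(=O)N2c2cccnc2)c1`, which carries pyridin-3-yl, gives > 1000 nM. That value is a limit of the assay and not a number. Compound 2 `Cc1ccnc(N2C(=O)CSC2c2cccc(C(=O)NCCCCn3cccn3)c2)c1`, with 4-methylpyridin-2-yl, gives 19.6 nM, and compound 3 `CCOC(=O)c1sc(N2C(=O)CSC2c2cccc(C(=O)NCCCCn3cccn3)c2)nc1C`, with 5-(ethoxycarbonyl)-4-methyl-1,3-thiazol-2-yl, gives 430 nM. Compound 3 therefore has the higher of the two true numbers, and the gap is large: a 22-fold higher number from compound 2 to compound 3 (1.34 log units; beyond the scatter).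

Compound 4 `O=C(NCCCCn1cccn1)c1cccc(C2SCC(=O)N2c2ccncc2)c1` keeps the rest of compound 3 but has pyridin-4-yl in place of the thiazole group on the amide-type nitrogen in the ring: pyridin-4-yl in place of 5-(ethoxycarbonyl)-4-methyl-1,3-thiazol-2-yl on an amide-type nitrogen in a ring.

Three measured steps changed this same place. The nearest guide is compound 1, whose group is also an unsubstituted pyridine, and an at least 2.3-fold lower number from compound 1 to compound 3 (0.36 log units; beyond the scatter) is at least modest. Reversing that step suggests a higher number for compound 4 than for compound 3. A caution comes from compound 2, a pyridine bearing a methyl group, since an at least 51-fold lower number from compound 1 to compound 2 (1.70 log units; beyond the scatter) is large and shows that changes at this place can matter greatly. The size of the rise is therefore uncertain, but a moderate step towards weaker inhibition seems likely. The expected change is a 2.3-fold higher number from compound 3 to compound 4 (0.37 log units; beyond the scatter). Compound 4 is expected at about 1000 nM, with an estimated range from 200 nM to 4000 nM, and the assay may report only a limit.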

Compound 4, half-maximal inhibitory concentration: > 1000 nM
Compound 4: a limit, no number (the forecaster's own chance of this, stated with the estimate: 50%); the middle value lies on the limit itself.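

In this assay, the result adds a second pyridine without a substituent at this position, and an at least 2.3-fold higher number from compound 3 to compound 4 (0.36 log units; beyond the scatter) shows that pyridin-4-yl gives weaker inhibition than the thiazole group of compound 3, despite being the smaller group. The comparison with a methyl-bearing pyridine is sharper still: an at least 51-fold higher number from compound 2 to compound 4 (1.70 log units; beyond the scatter), so among the pyridines shown, strong inhibition is seen only with 4-methylpyridin-2-yl, while pyridin-3-yl and pyridin-4-yl both fail to give a number. The step between compound 1 and compound 4 cannot be read, and no order can be given for these two pyridines, because both compounds stand at a limit of the assay and not at a number: the limit of > 1000 nM in this assay, at which 2 of the 4 values shown sit.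

4-methylpyridin-2-yl differs from pyridin-4-yl both in its methyl group and in the ring atom through which it is attached, and the compounds shown do not separate these two changes. From the compounds shown here alone, it remains open whether plain pyridin-2-yl, or a pyridin-2-yl ring carrying an amine or a longer chain in place of the methyl group, would keep the strong inhibition of compound 2.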